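The source may hold more compounds than are shown below. What is called first, only, known or untested is meant among the compounds shown, and "the series" means these compounds.

Compound 1 `CCC1=C(O)c2c(oc(-c3ccc(CC)cc3)cc2=O)C(CC)(CC)C1=O`: 0.07 uM
Compound 2 `CCC1=C(O)c2c(oc(-c3ccccc3OC)cc2=O)C(CC)(CC)C1=O`: 3.26 uM
Compound 3 `CCC1=C(O)c2c(oc(-c3ccc(C)c(Cl)c3)cc2=O)C(CC)(CC)C1=O`: 2.15 uM
Compound 4 `CCC1=C(O)c2c(oc(-c3ccc(C)c(F)c3)cc2=O)C(CC)(CC)C1=O`: not yet measured

All values come from a functional assay on KBVIN cells (Homo sapiens) for antiproliferative activity, read by sulforhodamine B assay, with a stated time of 3 days; on this read-out lower numbers stand for an effect already at smaller amounts and higher numbers for an effect only at larger amounts of compound. Compound 3 lies within the scatter of compound 2, with a 1.5-fold lower number from compound 2 to compound 3 (0.18 log units; within the scatter). Both lie far from compound 1, and the gap to compound 3 is a 31-fold higher number from compound 1 to compound 3 (1.49 log units; beyond the scatter).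

The next change is fluoro in place of chloro on an aromatic carbon, ortho to a methyl group and meta to a large group. For the measured compounds named here, no measured pair isolates this swap, since each measured step replaces the whole aryl group. The steps of a 47-fold higher number from compound 1 to compound 2 (1.67 log units; beyond the scatter) and a 31-fold higher number from compound 1 to compound 3 (1.49 log units; beyond the scatter) are large, so this position of the series can move the number strongly. However, both exchange entire substituted phenyl groups, a much larger edit than the exchange of one halogen. The step of a 1.5-fold lower number from compound 2 to compound 3 (0.18 log units; within the scatter) shows that a different aryl group need not shift the number at all.

A small step in this assay is therefore expected, most likely within the scatter. There is a slight lean towards a lower number, as compound 1, at 0.07 uM, carries no chloro, though this rests on one compound. The expected step is a 1.8-fold lower number from compound 3 to compound 4 (0.25 log units; within the scatter). The estimate for compound 4 is 1.2 uM, with an expected range from 0.25 uM to 4.5 uM.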

Compound 4, concentration for half-maximal effect: 2.95 uM
The estimate for compound 4 lay 2.5-fold (0.39 log units) below the measured number, within the range that was stated.
By their numbers in this assay, from the lowest: compound 1; then compounds 3, 4 and 2 (each within the scatter of the next).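

In this assay, the exchange of chloro for fluoro on an aromatic carbon ortho to a methyl group is now isolated, and the result is a 1.4-fold higher number from compound 3 to compound 4 (0.14 log units; within the scatter), so this one-atom edit leaves the number in place, unlike the large steps seen when the whole aryl group changes. The aryl comparisons agree, with a 1.1-fold lower number from compound 2 to compound 4 (0.04 log units; within the scatter) and a 42-fold higher number from compound 1 to compound 4 (1.62 log units; beyond the scatter), so the large gap to the 4-ethylphenyl group of compound 1 stays with either halogen, and replacing chloro with fluoro does not close it. No measurement available here explains why the swap leaves the number unchanged or why compound 1 stands apart.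

The compounds shown leave open which feature of the 4-ethylphenyl group separates compound 1 from the others, and whether a longer chain such as propyl in its place would hold the low number. They also leave open whether a group of another kind at the halogen position, such as an amine or a nitrile, would move the number, since only chloro and fluoro can be compared there.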